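Methyl in place of hydrogen on the phenyl group

The source may hold more compounds than are shown below. What is called first, only, known or untested is meant among the compounds shown, and "the series" means these compounds.

Among the compounds with values here, compound 1 `Cn1nc(-c2nnc(-c3ccccc3)o2)c2ccccc21` stands, in a functional assay on HepG2 cells (Homo sapiens) for antiproliferative activity, read by MTT assay, with a stated time of 72 h (on this read-out higher numbers stand for weaker inhibition and lower numbers for stronger inhibition), at the highest of the two numbers so far obtained: compound 1 gives 37500 nM. Its nearest neighbour is compound 2 `Cn1nc(-c2nnc(-c3cccc(Cl)c3)o2)c2ccccc21`, which carries chloro in place of hydrogen on an aromatic carbon; in this assay compound 2 gives 21400 nM. The step between them, a 1.8-fold lower number from compound 1 to compound 2 (0.24 log units; within the scatter), is small. Compound 3 `Cc1cccc(-c2nnc(-c3nn(C)c4ccccc34)o2)c1` has not yet been measured. It differs from compound 1 by methyl in place of hydrogen on an aromatic carbon; read one bond further out, the difference is phenyl to 3-methylphenyl. Within the data shown here, the only measured step that bears on this change is the one with chloro entering on an aromatic carbon, and since that step was a 1.8-fold lower number from compound 1 to compound 2 (0.24 log units; within the scatter), a step of similar size, or none beyond the scatter, is expected in this assay. Compound 3 is therefore estimated at 30000 nM, within 12000 nM to 75000 nM, an expected step of a 1.3-fold lower number from compound 1 to compound 3 (0.10 log units; within the scatter).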

Compound 3, half-maximal inhibitory concentration: 60000 nM
Compound 3: middle estimate off by 2.0-fold (0.30 log units), on the low side; low and high end bracket the measured number.
By their numbers in this assay, from the lowest: compounds 2, 1 and 3 (each within the scatter of the next, the first and the last beyond it).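

In this assay, methyl on this aromatic carbon gives a 1.6-fold higher number from compound 1 to compound 3 (0.20 log units; within the scatter), so neither methyl nor chloro at this place has yet moved the number beyond the scatter from that of compound 1. Within the data shown here, exchanging one group for the other at the same carbon gives the first step to pass the scatter, a modest 2.8-fold higher number from compound 2 to compound 3 (0.45 log units; beyond the scatter), which separates the two groups from each other but neither of them from hydrogen. No measurement at hand accounts for this difference between methyl and chloro.

The compounds shown leave open whether an amine or a carboxylic acid at this place would shift the number beyond the scatter from that of compound 1. They also leave open whether methyl or chloro would read the same on another carbon of the phenyl group.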